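The compounds below may be only part of what the source reports. "The series", "measured", "known", "first", "only" and "open" are said of these compounds alone.

Compound 1 `CSS[C@H]1C(O)[C@@H](CO)O[C@H]1n1ccc(=O)[nH]c1=O`: 220000 nM
Compound 2 `CSS[C@H]1C(O)[C@@H](CO)O[C@H]1n1ccc(N)nc1=O`: 255000 nM

In a functional assay on MOLT-4 cells (Homo sapiens) for antiproliferative activity (a higher number here means a weaker inhibitor, a lower number a stronger inhibitor), compound 1 gives 220000 nM, and compound 2 gives 255000 nM. These two numbers lie within the usual scatter of each other, so the two compounds cannot be told apart; both are weak inhibitors. Compound 3 `Nc1ccn([C@@H]2O[C@H](CO)C(O)[C@@H]2S)c(=O)n1` is compound 2 with hydrogen in place of methylsulfanyl on a sulfur; cut one bond further out, the change reads (methylsulfanyl)sulfanyl to sulfanyl. Within the data shown here, no measured pair shows this change, so its effect is unknown from these data. Expected is a step of a 1.3-fold lower number from compound 2 to compound 3 (0.11 log units; within the scatter), nothing beyond the scatter. In this assay compound 3 is expected to give about 200000 nM, between 50000 nM and 700000 nM.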

Compound 3, half-maximal inhibitory concentration: 650000 nM
Estimate against measurement, compound 3: 3.3-fold (0.51 log units) below; low and high end bracket the measured number.
By their numbers in this assay, from the lowest: compounds 1 and 2 (each within the scatter of the next); then compound 3.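

Replacing methylsulfanyl with hydrogen on this sulfur gives a 2.5-fold higher number from compound 2 to compound 3 (0.41 log units; beyond the scatter) in this assay and shows that the group on this sulfur matters to the read-out. Compound 1 and compound 2 alone could not show this. The effect is modest, and compound 3, with its bare sulfanyl, is the weaker inhibitor of this pair.

From the compounds shown here alone, whether a longer chain such as ethyl in place of methyl would lower the number stays open, as does the size of this step on compound 1. No measurement here explains the step.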